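This account rests on a few compounds, and the source may have more. Where it says the series, first, only, none or still open, it means among the compounds named here.

Compound 2 `Cc1nnsc1CO/N=C/c1c(C)nn(C)c1Oc1ccc(F)cc1` carries a 4-fluorophenyl ether on the shared core. In a functional assay on PANC-1 cells (Homo sapiens) for inhibition, read by MTT assay, with a stated time of 48 h (on this read-out lower numbers stand for stronger inhibition and higher numbers for weaker inhibition), compound 2 gives only a limit of the assay, > 50000 nM. Compound 1 `Cc1nnsc1CO/N=C/c1c(C)nn(C)c1Oc1ccccc1Cl` likewise gives a limit in this assay, > 50000 nM. Compound 3 `Cc1nnsc1CO/N=C/c1c(C)nn(C)c1Oc1ccccc1OC(F)(F)F` also sits at a limit, > 50000 nM. The step from compound 1 to compound 2, a step that the two limits leave unreadable from compound 1 to compound 2, and the step from compound 1 to compound 3, a step that the two limits leave unreadable from compound 1 to compound 3, cannot be sized because of the limit of > 50000 nM in this assay, at which 3 of the 3 values shown sit. Compound 2 therefore stands with the other two at the limit. Compound 4 `Cc1nnsc1CO/N=C/c1c(C)nn(C)c1Oc1ccc(OC(F)(F)F)cc1` differs from compound 2 by trifluoromethoxy in place of fluoro on an aromatic carbon. The measured steps offer no readable direction for this change. Compound 4 is expected to give 80000 nM, with a range from 30000 nM to 300000 nM. The estimated step that the limit leaves unreadable from compound 2 to compound 4 is expected to stay within the scatter, most likely again at a limit.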

Compound 4, half-maximal inhibitory concentration: > 50000 nM
Compound 4: no number, only a limit (the forecaster's own chance of this, stated with the estimate: 80%); the middle value does not contradict the limit.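

The step between compound 2 and compound 4 cannot be read, as both compounds give only a limit: the limit of > 50000 nM in this assay, at which 4 of the 4 values shown sit. The compounds shown leave open whether any group on this aromatic ring would give a measurable value in this assay.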